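The source may report more compounds than this note shows. Statements on the series, on what has been measured and on what is new or still open speak of the compounds shown alone.

Measured so far, in a functional assay on Hep 3B2 cells (Homo sapiens) for inhibition, read by MTT assay, with a stated time of 72 h; a lower number here means a stronger inhibitor, a higher number a weaker inhibitor: compound 1 `CNC(=O)CCCCCCCn1nc(-c2cnc3[nH]ccc3c2)c2c(N)ncnc21` gives 16300 nM; compound 2 `Nc1ncnc2c1c(-c1cnc3[nH]ccc3c1)nn2CCCCCCCCC(=O)NO` gives 8390 nM; compound 3 `Nc1nc2cc(-c3nn(CCCCCCCCC(=O)NO)c4ncnc(N)c34)ccc2o1` gives 8890 nM.

Compound 4 `CNC(=O)CCCCCCCn1nc(-c2ccc3oc(N)nc3c2)c2c(N)ncnc21` has not yet been measured. It differs from compound 3 by methylcarbamoyl in place of (hydroxycarbamoyl)methyl on a saturated chain carbon, seven bonds along the chain from an aromatic nitrogen, and the same change was made between two measured compounds, as methylcarbamoyl in place of (hydroxycarbamoyl)methyl on a saturated chain carbon, seven bonds along the chain from an aromatic nitrogen, where it gave a 1.9-fold higher number from compound 2 to compound 1 (0.29 log units; within the scatter). Compound 3 and compound 4 differ from compound 2 and compound 1 in the core, as a group of 10 heavy atoms (7 carbon, 2 nitrogen, 1 oxygen; one five-membered aromatic ring with 2 hetero atoms, one six-membered aromatic ring of carbon only) in place of a group of 9 heavy atoms (7 carbon, 2 nitrogen; one five-membered aromatic ring with 1 hetero atom, one six-membered aromatic ring with 1 hetero atom), on an aromatic carbon, a swap that gave a 1.1-fold higher number from compound 2 to compound 3 (0.03 log units; within the scatter).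

For the measured compounds named here, because compound 3 sits at 8890 nM and the one earlier instance of this change moved by a 1.9-fold higher number from compound 2 to compound 1 (0.29 log units; within the scatter), compound 4 is expected to shift by about a 1.9-fold higher number from compound 3 to compound 4 (0.28 log units; within the scatter). Compound 4 is estimated at 17000 nM, expected to fall between 7000 nM and 40000 nM.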

Compound 4, half-maximal inhibitory concentration: 10300 nM
Compound 4: the middle estimate sits 1.7-fold (0.22 log units) above what was measured; the range from low to high includes it.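

In this assay, putting methylcarbamoyl in place of (hydroxycarbamoyl)methyl gives (a 1.2-fold higher number from compound 3 to compound 4 (0.06 log units; within the scatter)), and the group swap on the aromatic carbon gives (a 1.6-fold lower number from compound 1 to compound 4 (0.20 log units; within the scatter)). The methylcarbamoyl change behaves alike on both cores, as far as this assay can tell: the same change on two cores in this assay, a 1.9-fold higher number (0.29 log units; within the scatter) from compound 2 to compound 1 and a 1.2-fold higher number (0.06 log units; within the scatter) from compound 3 to compound 4, 1.7-fold (0.22 log units) apart, within the scatter of two such steps. For the compounds shown here, the group swap also shows no detectable dependence on what else the compound carries, but every step here lies within the scatter, so this shows only that neither change moved the number measurably, not that either has a dependable effect of any particular size: the same change on two cores in this assay, a 1.1-fold higher number (0.03 log units; within the scatter) from compound 2 to compound 3 and a 1.6-fold lower number (0.20 log units; within the scatter) from compound 1 to compound 4, 1.7-fold (0.22 log units) apart, within the scatter of two such steps.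

The compounds shown leave open whether a longer chain, or a carboxylic acid in place of methylcarbamoyl, would shift the number beyond the scatter.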